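A few compounds are considered here, and "the series" means these few. Any claim that something is new, unique, unknown or untested is made for them only; others in the source may bear on it.

Three compounds share one core, each carrying a chain that ends in a carbonyl bearing an aromatic ring. Compound 1 is `COc1cc(-c2cc(/C=C/C(=O)c3ccc(Cl)c(Cl)c3)[nH]n2)cc(OC)c1OC`, and in a functional assay on NCI-H522 cells (Homo sapiens) for cytotoxicity, read by sulforhodamine B assay, with a stated time of 48 h, tested at 100 uM (a higher number here means a weaker effect of the compound at the concentration tested, a lower number a stronger effect), compound 1 gives -65%. Compound 2 is `COc1ccc(-c2cc(/C=C/C(=O)c3cc(OC)c(OC)c(OC)c3)[nH]n2)cc1OC`, and in this assay compound 2 gives -90%. Compound 3 is `COc1ccc(-c2cc(/C=C/C(=O)c3ccc(N)cc3)[nH]n2)cc1`, and in this assay compound 3 gives -75%. Among these three numbers the one for compound 1 is the highest; its gap to compound 3 lies within the usual scatter of such measurements, while its gap to compound 2 lies beyond it.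

Compound 4 is `COc1cc(-c2cc(/C=C/C(=O)c3ccc(F)c(F)c3)[nH]n2)cc(OC)c1OC`. It differs from compound 1 in one place: 3,4-difluorophenyl in place of 3,4-dichlorophenyl on a carbonyl carbon. Among the compounds with values here, no measured pair in this set shows what such an exchange does, so the size of the step can only be judged from the spread of the numbers seen so far. A small step is expected, not reaching beyond the scatter. The step from compound 1 to compound 4 is estimated as a number 10 percentage points higher from compound 1 to compound 4 (within the scatter). In this assay compound 4 is expected to give -55%, with a range from -80% to -20%.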

Compound 4, a percentage reported as activity, at one concentration (the size of the read-out at that concentration, not a potency): -53%
For compound 4 the middle estimate is 2 percentage points below the measured one; the range from low to high includes it.
By their numbers in this assay, from the lowest: compound 2; then compounds 3 and 1 (each within the scatter of the next); then compound 4.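

In this assay, within the data shown here, the exchange of 3,4-dichlorophenyl for 3,4-difluorophenyl on a carbonyl carbon gives a number 12 percentage points higher from compound 1 to compound 4 (beyond the scatter), the first comparison in this set in which only one place changes. A higher number means a weaker effect, so this position is sensitive to which halogen the ring carries, although the step is modest and compound 4, at -53% in this read-out, keeps much of the effect. Nothing measured on these two groups accounts for the step.

This single pair cannot show whether 3,4-dibromophenyl or an unsubstituted phenyl on the same carbonyl carbon would continue the trend or break it. It also leaves open whether the same exchange would produce a similar step on a different core, or how the two compounds would compare at lower concentrations.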